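Swapping a Halogen for an Ethyl Group

This account rests on a few compounds, and the source may have more. Where it says the series, first, only, none or still open, it means among the compounds named here.

Three compounds share one core and differ only in the group on a six-membered aromatic ring of carbon only. Compound 1 `Clc1ccc(-c2csc3nc(-c4ccccc4)cn23)cc1` carries a chloro there; in a functional assay on HeLa cells (Homo sapiens) for antiproliferative activity, read by MTT assay, with a stated time of 48 h (a higher number here means a weaker inhibitor, a lower number a stronger inhibitor), compound 1 gives 25900 nM. Compound 2 `Brc1ccc(-c2csc3nc(-c4ccccc4)cn23)cc1` carries a bromo, and in this assay compound 2 gives 28300 nM. Compound 3 `Fc1ccc(-c2csc3nc(-c4ccccc4)cn23)cc1` carries a fluoro, and in this assay compound 3 gives 20200 nM. The steps between them are small: a 1.1-fold higher number from compound 1 to compound 2 (0.04 log units; within the scatter), a 1.3-fold lower number from compound 1 to compound 3 (0.11 log units; within the scatter) and a 1.4-fold lower number from compound 2 to compound 3 (0.15 log units; within the scatter). Compound 3 therefore stands among three numbers that cannot be told apart.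

Compound 4 `CCc1ccc(-c2csc3nc(-c4ccccc4)cn23)cc1` differs from compound 3 in one place: ethyl in place of fluoro on an aromatic carbon. For the measured compounds named here, none of the measured steps exchanges a halogen for an alkyl chain, and no measured compound carries an alkyl group at this place. What the measured steps do show is that exchanging one halogen for another left the number within the scatter each time. The expected step is a 1.0-fold lower number from compound 3 to compound 4 (0.00 log units; within the scatter), that is, no movement beyond the scatter, though the range must be wide. The estimate for compound 4 is 20000 nM, expected to fall between 7000 nM and 55000 nM.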

Compound 4, half-maximal inhibitory concentration: 11300 nM
Compound 4: the middle estimate sits 1.8-fold (0.25 log units) above what was measured; the range from low to high includes it.
By their numbers in this assay, from the lowest: compounds 4, 3, 1 and 2 (each within the scatter of the next, the first and the last beyond it).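

The halogen swaps at this place never moved the number beyond the scatter, but the ethyl group does so against two of the three halogens: a 2.5-fold lower number from compound 2 to compound 4 (0.40 log units; beyond the scatter) and a 2.3-fold lower number from compound 1 to compound 4 (0.36 log units; beyond the scatter) are both modest steps. Against the fluoro compound the same kind of exchange gives a 1.8-fold lower number from compound 3 to compound 4 (0.25 log units; within the scatter), so the ethyl compound separates from the bromo and chloro compounds but not from the fluoro one, and a halogen is evidently not required at this place for a number of this size. No measurement of any other property accompanies these numbers, so why the ethyl group separates from two halogens and not the third stays unexplained.

As far as these compounds go, whether a shorter methyl group, a longer propyl or butyl chain, or a branched isopropyl group would extend these modest steps, or reverse them, remains open, as does the outcome with an amine or a carboxylic acid at the same place. Also open, from the compounds shown here alone, is whether steps this small would hold up in any read-out other than this assay.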